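This account rests on a few compounds, and the source may have more. Where it says the series, first, only, none or still open, it means among the compounds named here.

Of the compounds shown here, three that share a common core have been measured in a functional assay on T47D cells (Homo sapiens) for inhibition, read by sulforhodamine B assay, with a stated time of 48 h; a higher number here means a weaker inhibitor of growth, a lower number a stronger inhibitor of growth. Compound 1 `COc1ccc(-c2cc(/C=C/C(=O)c3ccc(N)cc3)[nH]n2)cc1` gives 1470 nM. Compound 2 `COc1cc(-c2cc(/C=C/C(=O)c3ccc(N)cc3)[nH]n2)cc(OC)c1OC` gives 1420 nM. Compound 3 `COc1cc(-c2cc(/C=C/C(=O)c3ccc(Cl)c(Cl)c3)[nH]n2)cc(OC)c1OC` gives 1660 nM. On these numbers compound 3 sits alongside compound 1 and compound 2, all three within the scatter of one another, so none of them can be called the stronger or weaker growth inhibitor.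

Within the data shown here, only one single-site step links two of the measured compounds: a 1.2-fold higher number from compound 2 to compound 3 (0.07 log units; within the scatter), an exchange of the group on the carbonyl carbon that left the number essentially where it was.

Compound 4 `COc1cc(-c2cc(/C=C/C(=O)c3ccc(F)c(F)c3)[nH]n2)cc(OC)c1OC` has not yet been measured. It differs from compound 3 by 3,4-difluorophenyl in place of 3,4-dichlorophenyl on a carbonyl carbon. Among the measured compounds shown here, no measured step exchanges one halogen for another on this group; the only measured step at this carbonyl carbon, a 1.2-fold higher number from compound 2 to compound 3 (0.07 log units; within the scatter), was within the scatter. The step from compound 3 to compound 4 is therefore expected to be a 1.0-fold lower number from compound 3 to compound 4 (0.02 log units; within the scatter), nothing beyond the scatter. In this assay compound 4 is estimated at 1600 nM, expected to fall between 700 nM and 3600 nM.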

Compound 4, concentration for 50% growth inhibition: 2450 nM
Compound 4: the middle estimate sits 1.5-fold (0.19 log units) below what was measured; the range from low to high includes it.
By their numbers in this assay, from the lowest: compounds 2, 1, 3 and 4 (each within the scatter of the next).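

In this assay, exchanging the two chlorines of the group on the carbonyl carbon for two fluorines gives a 1.5-fold higher number from compound 3 to compound 4 (0.17 log units; within the scatter), so this halogen exchange does not separate the two compounds. Replacing the 4-aminophenyl group with 3,4-difluorophenyl gives a 1.7-fold higher number from compound 2 to compound 4 (0.24 log units; within the scatter), which means that all three groups at this position, on the trimethoxy-bearing compounds 2, 3 and 4, now stand within the scatter of one another. No measurement is available that could explain these numbers.

From the compounds shown here alone, it remains open whether a group of a different kind on the carbonyl carbon, such as a carboxylic acid or an open-chain amine in place of the aromatic ring, would move the number beyond the scatter. Also open is whether either halogenated group would give a similar number on compound 1, which is shown only with 4-aminophenyl.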